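The source may hold more compounds than are shown below. What is called first, only, known or untested is meant among the compounds shown, and "the series" means these compounds.

Compound 1 `COc1cc(OC)nc(N2C(=O)CSC2c2c(F)cccc2F)n1`: 77500 nM in an ADME assay on TZM cells (Homo sapiens) for cytotoxicity, read by MTT assay, with a stated time of 48 h; on this read-out higher numbers stand for lower toxicity in this test and lower numbers for higher toxicity in this test
Compound 2 `COc1cc(OC)nc(N2C(=O)CSC2c2c(F)cccc2Cl)n1`: 98200 nM in this assay

Compound 2 holds the highest of the two numbers in this assay; the other lies within the scatter of it, a 1.3-fold higher number from compound 1 to compound 2 (0.10 log units; within the scatter). Compound 3 `COc1cc(OC)nc(N2C(=O)CSC2c2ccc(C#N)cc2)n1` has not yet been measured and differs from compound 2 by 4-cyanophenyl in place of 2-chloro-6-fluorophenyl on a saturated ring carbon. Within the data shown here, only one measured step exists, a 1.3-fold higher number from compound 1 to compound 2 (0.10 log units; within the scatter), a halogen exchange on the same ring that moved nothing beyond the scatter and bears only loosely on this larger exchange of the whole aryl group. With so little to go on, compound 3 is expected near 80000 nM, between 30000 nM and 200000 nM. The expected step is a 1.2-fold lower number from compound 2 to compound 3 (0.09 log units; within the scatter), not beyond the scatter.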

Compound 3, half-maximal cytotoxic concentration: 86500 nM
Estimate against measurement, compound 3: 1.1-fold (0.03 log units) below, and the stated range covers the measured number.
By their numbers in this assay, from the lowest: compounds 1, 3 and 2 (each within the scatter of the next).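

In this assay the earlier pair had shown only a halogen exchange, whereas here the whole aryl group on the saturated ring carbon is exchanged for 4-cyanophenyl, and the step stays within the scatter both from 2-chloro-6-fluorophenyl (a 1.1-fold lower number from compound 2 to compound 3 (0.06 log units; within the scatter)) and from 2,6-difluorophenyl (a 1.1-fold higher number from compound 1 to compound 3 (0.05 log units; within the scatter)). Among these three compounds, then, the number does not depend on the ring carrying a halogen. Nothing available explains this result.

From the compounds shown here alone, all three compounds carry a six-membered aromatic carbon ring at this position, so it remains open whether an amine or a carboxylic acid on that ring, or a longer alkyl chain in its place, would move the number beyond the scatter.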